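A few compounds are considered here, and "the series" means these few. Any claim that something is new, unique, unknown or untested is made for them only; others in the source may bear on it.

Compound 1 `COc1cc(Cl)cc(-c2nn(-c3cccc(NC(=O)Nc4ccc(Cl)c(C(F)(F)F)c4)c3)cc2-c2ccncc2)c1` sits second highest of the three numbers in a functional assay on ACHN cells (Homo sapiens) for inhibition, read by sulforhodamine B assay, with a stated time of 48 h, tested at 1 uM (on this read-out higher numbers stand for a weaker effect at the one concentration tested and lower numbers for a stronger effect), where compound 1 gives 45%. Its nearest neighbour is compound 2 `COc1cc(Cl)cc(-c2nn(-c3cccc(NC(=O)Nc4cc(C(F)(F)F)cc(C(F)(F)F)c4)c3)cc2-c2ccncc2)c1`, which in this assay gives 17%, and the furthest is compound 3 `COc1cc(Cl)cc(-c2nn(-c3cccc(NC(=O)Nc4ccc(Cl)c(Cl)c4)c3)cc2-c2ccncc2)c1`, which in this assay gives 91%. Among the compounds with values here, the single measured step, a number 46 percentage points higher from compound 1 to compound 3 (beyond the scatter), shows that the substituent on the outer aryl ring of the urea moves the read-out far beyond the scatter.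

Compound 4 `COc1cc(Cl)cc(-c2nn(-c3cccc(NC(=O)Nc4cccc(C(F)(F)F)c4)c3)cc2-c2ccncc2)c1` differs from compound 1 by hydrogen in place of chloro on an aromatic carbon, ortho to a trifluoromethyl group. Within the data shown here, no measured step removes a chloro from this ring, so the only guide is the large step from compound 1 to compound 3, which shows this ring to be sensitive. Because compound 3 gives 91% when the trifluoromethyl is lost, the step from compound 1 to compound 4 is expected to run upward, to a weaker effect, by a number 20 percentage points higher from compound 1 to compound 4 (beyond the scatter). Compound 4 is therefore estimated at 65%, within 40% to 90%.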

Compound 4, a percentage reported as activity, at one concentration (the size of the read-out at that concentration, not a potency): 65%
Estimate against measurement, compound 4: no gap at the digits printed, and the stated range covers the measured number.
By their numbers in this assay, from the lowest: compound 2; then compound 1; then compound 4; then compound 3.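

In this assay the chloro ortho to a trifluoromethyl group proves to count in its own right: going to the 3-(trifluoromethyl)phenyl group gives a number 20 percentage points higher from compound 1 to compound 4 (beyond the scatter) and so a weaker effect, though not one as weak as that of the 3,4-dichlorophenyl group. That lone trifluoromethyl still outperforms the two chloro groups, with a number 26 percentage points lower from compound 3 to compound 4 (beyond the scatter) toward a stronger effect, while hydrogen in place of the second trifluoromethyl costs far more, with a number 48 percentage points higher from compound 2 to compound 4 (beyond the scatter) toward a weaker effect. No evidence at hand accounts for these shifts.

The compounds shown leave open how a fluoro, a methoxy or a nitrile would read in place of the chloro on the 3-(trifluoromethyl)phenyl ring. They also leave open whether an amine or a carboxylic acid on that ring would keep the effect seen with the trifluoromethyl groups.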